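Cyano in place of isopropoxy on the pendant phenyl

This account rests on a few compounds, and the source may have more. Where it says the series, first, only, none or still open, it means among the compounds named here.

Compound 3 `COc1ccc(CN2C(=O)C(=O)c3cc(-c4ccc(OC(C)C)cc4)ccc32)cc1` is measured in a functional assay on HepG2 cells (Homo sapiens) for antiproliferative activity, read by MTT assay, with a stated time of 48 h (on this read-out lower numbers stand for stronger inhibition and higher numbers for weaker inhibition), only up to a limit: compound 3 gives > 10000 nM, which is the limit of the assay and not a number. Compound 1 `COc1ccc(CN2C(=O)C(=O)c3cc(-c4ccc(OC)cc4)ccc32)cc1` in this assay gives 50 nM. Compound 2 `COc1ccc(CN2C(=O)C(=O)c3cc(-c4ccc(F)c(Cl)c4)ccc32)cc1` gives > 10000 nM, again a limit. Two of the three values therefore sit at the limit of > 10000 nM in this assay, at which 2 of the 3 values shown sit. Among the compounds with values here, the only readable steps are an at least 200-fold higher number from compound 1 to compound 3 (2.30 log units; beyond the scatter) and an at least 200-fold higher number from compound 1 to compound 2 (2.30 log units; beyond the scatter); the step that the two limits leave unreadable from compound 2 to compound 3 cannot be read. Compound 4 `COc1ccc(CN2C(=O)C(=O)c3cc(-c4ccc(C#N)cc4)ccc32)cc1` differs from compound 3 by cyano in place of isopropoxy on an aromatic carbon. Because the number for compound 3 is > 10000 nM, a limit, the expected step of an at least 5.0-fold lower number from compound 3 to compound 4 (0.69 log units; beyond the scatter) can only be read as a move toward a measurable value. Compound 4 is estimated at 2000 nM, in the range 200 nM to 10000 nM.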

Compound 4, half-maximal inhibitory concentration: 890 nM
For compound 4 the middle estimate is 2.2-fold (0.35 log units) above the measured one, within the range that was stated.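

In this assay, a group other than methoxy at this position on the pendant phenyl can still give a measurable value, as cyano shows with an at least 11-fold lower number from compound 3 to compound 4 (1.05 log units; beyond the scatter) and an at least 11-fold lower number from compound 2 to compound 4 (1.05 log units; beyond the scatter). Cyano does not match methoxy, however, with an 18-fold higher number from compound 1 to compound 4 (1.25 log units; beyond the scatter). The first two steps start from limits of the assay, not numbers: the limit of > 10000 nM in this assay, at which 2 of the 4 values shown sit.

The four groups shown give no rule linking group to value. An ethoxy group, an amine or a carboxylic acid at this position could land near compound 1, near compound 4 or at the limit.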